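Series notes: diamino core with aryl substituent changes

The source may report more compounds than this note shows. Statements on the series, on what has been measured and on what is new or still open speak of the compounds shown alone.

Three measured members share one core. Compound 1 `CCOC(=O)[C@H](CCC(=O)O)NC(=O)c1ccc(Sc2nc3cc(N)cc(N)c3nc2-c2ccccc2)cc1` gives 21400 nM in a functional assay on NCI/ADR-RES cells (Homo sapiens) for inhibition, read by sulforhodamine B assay, with a stated time of 48 h; a higher number here means a weaker inhibitor of growth, a lower number a stronger inhibitor of growth. Compound 3 `CCOC(=O)[C@H](CCC(=O)O)NC(=O)c1ccc(Oc2nc3cc(N)cc(N)c3nc2-c2ccccc2)cc1` gives 27500 nM in this assay. Compound 2 `Nc1cc(N)c2nc(-c3ccccc3)c(Sc3ccc(F)cc3)nc2c1` gives 16600 nM in this assay; this is the lowest of the three numbers, but the gaps to compound 1 and to compound 3 both lie within the scatter, so no order among them can be claimed.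

Compound 4 `Nc1cc(N)c2nc(-c3ccccc3)c(NCc3ccc(F)cc3)nc2c1` differs from compound 2 in one place: (4-fluorobenzyl)amino in place of (4-fluorophenyl)sulfanyl on an aromatic carbon. For the measured compounds named here, no measured pair shows this kind of change, so its effect in this assay cannot be read from the data; the expectation is a step no larger than the scatter, in either direction. Compound 4 is therefore estimated at 15000 nM (range 5000 nM to 45000 nM), which means an expected step of a 1.1-fold lower number from compound 2 to compound 4 (0.04 log units; within the scatter).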

Compound 4, concentration for 50% growth inhibition: 2450 nM
Beside the measured number, compound 4's estimate is 6.1-fold (0.79 log units) above it; the measured number lies below the stated range.
By their numbers in this assay, from the lowest: compound 4; then compounds 2, 1 and 3 (each within the scatter of the next).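

In this assay, (4-fluorobenzyl)amino in place of (4-fluorophenyl)sulfanyl on this aromatic carbon gives a 6.8-fold lower number from compound 2 to compound 4 (0.83 log units; beyond the scatter). For the compounds shown here, this is the first step read at this position, and it shows that the group held there can move the number beyond the scatter. No measurement on hand gives a reason for the step.

The step cannot be divided between the amino nitrogen and the added carbon of the benzyl group. An anilino group, a benzyloxy group or a longer chain such as 2-phenylethylamino at this carbon would bear on that question.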